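Proline, Aminocyclohexyl and Leucine Amides on a Shared Core

A few compounds are considered here, and "the series" means these few. Any claim that something is new, unique, unknown or untested is made for them only; others in the source may bear on it.

Measured compounds:
- compound 1, `O=C(Nc1cc2cc[nH]c(=O)c2cc1Cl)[C@@H]1CCCN1`: "not determined" (no result reported)
- compound 2, `N[C@H]1CC[C@@H](C(=O)Nc2cc3cc[nH]c(=O)c3cc2Cl)CC1`: 180 nM

Compound 2 carries the 4-aminocyclohexyl amide on the shared core. In a functional assay (aorta) with Rattus norvegicus as the target (on this read-out higher numbers stand for an effect only at larger amounts of compound and lower numbers for an effect already at smaller amounts), compound 2 gives 180 nM, the only number shown in this series; compound 1, the proline amide, has no result, so no step between measured compounds can be read. Compound 3, `CC(C)C[C@@H](N)C(=O)Nc1cc2cc[nH]c(=O)c2cc1Cl`, differs from compound 2 in one place: 1-amino-3-methylbutyl in place of 4-aminocyclohexyl on a carbonyl carbon. The ring of compound 2 is thus replaced by an open chain carrying the amine, with the shared core untouched. Among the measured compounds shown here, with no measured step to lean on, the account expects a moderate loss of potency rather than a gain, and the expected step in this assay is a 2.2-fold higher number from compound 2 to compound 3 (0.35 log units; beyond the scatter), somewhat beyond the scatter. Compound 3 is therefore estimated at 400 nM, with a range from 100 nM to 1500 nM.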

Compound 3, half-maximal effective concentration: 700 nM
Beside the measured number, compound 3's estimate is 1.8-fold (0.24 log units) below it, and the stated range covers the measured number.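

In this assay this position, on a carbonyl carbon, now yields a first readable step, with a 3.9-fold higher number from compound 2 to compound 3 (0.59 log units; beyond the scatter) when the 4-aminocyclohexyl ring gives way to the open 1-amino-3-methylbutyl chain. The change therefore moves the read-out beyond the scatter, and the ring is not needed for a measurable effect, since the open chain, which also carries an amine, still gives a number. Nothing at hand bears on why the number rises.

Going by these compounds, compound 1 has no number, so steps involving the proline amide cannot be read, and its place relative to the ring and the open chain stays unknown. On these data alone, whether a longer chain, or a carboxylic acid in place of the amine, would keep or shift the number at this position also remains open.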